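The compounds below may be only part of what the source reports. "The series", "measured", "known", "first", "only" and "open" are said of these compounds alone.

Measured compounds:
Compound 1 `O=C(NCc1ccc(OCc2ccc(-c3nn[nH]n3)cc2)cc1)[C@@H]1CCC(=O)N1Cc1ccccc1` — > 5000 nM
Compound 2 `O=C(NCc1ccc(OCc2ccc(-c3nn[nH]n3)cc2)cc1)[C@@H]1CCC(=O)N1Cc1ccc(F)cc1` — > 5000 nM
Compound 3 `O=C(O)c1ccc(COc2ccc(CNC(=O)[C@@H]3CCCN3Cc3ccccc3)cc2)cc1` — > 5000 nM

All three were run in an assay on HEK293 cells for inhibition of Ataxin-2 (Mus musculus), read by fluorescence and Amplex Red; a higher number here means a weaker inhibitor, a lower number a stronger inhibitor. Compound 1 gives > 5000 nM, which is a limit of the assay and not a number. Compound 2 likewise gives > 5000 nM, again a limit. Compound 3 gives > 5000 nM, also a limit. Among the measured compounds shown here, the step that the two limits leave unreadable from compound 1 to compound 2 is therefore not readable, and the only evidence on the measured series is the limit of > 5000 nM in this assay, at which 3 of the 3 values shown sit.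

The change from compound 1 to compound 2 is fluoro in place of hydrogen on an aromatic carbon. The difference between the core of compound 1 and the core of compound 3 is not broken down here.

Compound 4 `O=C(O)c1ccc(COc2ccc(CNC(=O)[C@@H]3CCCN3Cc3ccc(F)cc3)cc2)cc1` is not yet measured. It differs from compound 3 by fluoro in place of hydrogen on an aromatic carbon; the place is the same word for word as in the change from compound 1 to compound 2, so this is the same change, occurring twice in the set. Because the limit of > 5000 nM in this assay, at which 3 of the 3 values shown sit, shows every value in this assay sitting at the limit, and because the pair compound 1 to compound 2 gave no readable step, there is no measured basis for expecting the change to move compound 4 off the limit.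

The step from compound 3 to compound 4 is expected to be about a step that the limit leaves unreadable from compound 3 to compound 4. Compound 4 is estimated at 9000 nM, with a range from 4000 nM to 25000 nM, most likely reported again as a limit.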

Compound 4, half-maximal inhibitory concentration: 800 nM
The estimate for compound 4 lay 11-fold (1.05 log units) above the measured number; measured number outside the range, below it.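

In this assay, as far as these compounds go, fluoro in place of hydrogen on an aromatic carbon, para to a large group, gives an at least 6.2-fold lower number from compound 3 to compound 4 (0.79 log units; beyond the scatter); the starting value is a limit of the assay and not a number, so this size is a minimum and the full size stays unknown. On this one core, then, phenyl to 4-fluorophenyl brings the number off the limit and gives a step beyond the scatter. Carrying the change from one core to another is not shown: the same change on the core of compound 1 gives compound 2, the step between those two cannot be read, and the series holds one readable case, which neither confirms nor rules out a gain on the other core: the limit of > 5000 nM in this assay, at which 3 of the 4 values shown sit.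

Still open, from the compounds shown here alone, is whether the gain belongs to fluoro itself or would also appear with chloro, methoxy or trifluoromethyl on the same aromatic carbon of the benzyl group. Also open, going by these compounds, is whether the number of compound 4 holds when its carboxylic acid gives way to an amine, or when a longer chain joins that acid to the rest of the molecule.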